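A few compounds are considered here, and "the series" means these few. Any claim that something is new, unique, unknown or untested is made for them only; others in the source may bear on it.

Values in a functional assay on HCT-116 cells (Homo sapiens) for antiproliferative activity, with a stated time of 72 h (on this read-out higher numbers stand for weaker inhibition and lower numbers for stronger inhibition), for the series so far:

compound 1 `CCCC#Cc1cc([C@@H]2O[C@H](CO)[C@@H](O)[C@H]2O)n2ncnc(N)c12` gives 200 nM
compound 2 `CCCCC#Cc1cc([C@@H]2O[C@H](CO)[C@@H](O)[C@H]2O)n2ncnc(N)c12` gives 2900 nM
compound 3 `COc1ccc(-c2cc([C@@H]3O[C@H](CO)[C@@H](O)[C@H]3O)n3ncnc(N)c23)cc1` gives 47100 nM

Compound 3 stands highest of these three. Compound 4 `Nc1ncnn2c([C@@H]3O[C@H](CO)[C@@H](O)[C@H]3O)cc(-c3ccccc3Cl)c12` differs from it as follows: 2-chlorophenyl in place of 4-methoxyphenyl on an aromatic carbon. Among the measured compounds shown here, no measured step exchanges one aromatic substituent for another, so the evidence is indirect. Putting 4-methoxyphenyl in place of pent-1-yn-1-yl or hex-1-yn-1-yl gave large steps (a 240-fold higher number from compound 1 to compound 3 (2.37 log units; beyond the scatter) and a 16-fold higher number from compound 2 to compound 3 (1.21 log units; beyond the scatter)), and one added methyl also gave a large step (a 15-fold higher number from compound 1 to compound 2 (1.16 log units; beyond the scatter)). None of these gives the direction for this exchange. A small step to a lower number is expected (a 1.9-fold lower number from compound 3 to compound 4 (0.28 log units; within the scatter)) and it may stay within the scatter. Compound 4 is estimated at 25000 nM with a range from 6000 nM to 80000 nM in this read-out.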

Compound 4, half-maximal inhibitory concentration: > 100000 nM
Compound 4 gave a limit, no number; the forecaster's own chance of this, stated with the estimate: 25%; middle value at least 4.0-fold (0.60 log units) from the limit.
By their numbers in this assay, from the lowest: compound 1; then compound 2; then compound 3. At a limit, above all of these: compound 4.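

Exchanging one substituted phenyl group for another at this aromatic carbon gives an at least 2.1-fold higher number from compound 3 to compound 4 (0.32 log units; beyond the scatter), so the read-out responds to the aryl group itself, not only to alkyne versus aryl. Against the alkynes, the steps are an at least 34-fold higher number from compound 2 to compound 4 (1.53 log units; beyond the scatter) and an at least 500-fold higher number from compound 1 to compound 4 (2.69 log units; beyond the scatter), each bounded on one side only. In this assay compound 4 gives a limit, not a number: the limit of > 100000 nM in this assay, at which 1 of the 4 values shown sits.

Compounds 3 and 4 differ in both the substituent and its place on the phenyl ring, so neither change can be read alone. On these data alone, whether a shorter alkyne, but-1-yn-1-yl, would fall below compound 1 stays open.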